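The source may report more compounds than this note shows. Statements on the series, on what has been measured and on what is new or still open speak of the compounds shown alone.

Compound 3 `C#Cc1cncc(C#Cc2ccc3ncn(-c4ccnc(N)n4)c3c2)c1` gives 63100 nM in an assay on Sf9 cells for inhibition of mitogen-activated protein kinase kinase kinase 14 variant S549D (Homo sapiens), with a stated time of 30 min, in the presence of a further agent that is not named here (on this read-out lower numbers stand for stronger inhibition and higher numbers for weaker inhibition), which is the highest of the three numbers recorded there. Compound 1 `C=CC(=O)NCC#Cc1ccc2ncn(-c3ccnc(N)n3)c2c1` gives 6310 nM in this assay, and compound 2 `C#Cc1cccc(C#Cc2ccc3ncn(-c4ccnc(N)n4)c3c2)n1` gives 3160 nM in this assay. The steps show a 10-fold higher number from compound 1 to compound 3 (1.00 log units; beyond the scatter) and a 20-fold higher number from compound 2 to compound 3 (1.30 log units; beyond the scatter), while a 2.0-fold lower number from compound 1 to compound 2 (0.30 log units; within the scatter).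

Compound 4 `C#Cc1nccc(C#Cc2ccc3ncn(-c4ccnc(N)n4)c3c2)n1` is not yet measured. It differs from compound 3 in a group of 8 heavy atoms (6 carbon, 2 nitrogen; one six-membered aromatic ring with 2 hetero atoms) in place of a group of 8 heavy atoms (7 carbon, 1 nitrogen; one six-membered aromatic ring with 1 hetero atom), on a triple-bonded carbon. Among the compounds with values here, the step that bears most directly on this change is the one from compound 2 to compound 3, in which one six-membered aromatic ring with one hetero atom replaced another of the same kind on the same triple-bonded carbon and a 20-fold higher number from compound 2 to compound 3 (1.30 log units; beyond the scatter). That step shows that exchanging the ring on this carbon can shift the number by a large amount, and in either direction depending on which ring enters. The step from compound 1 to compound 3 adds that compound 3 sits well above an open-chain group at this position. Since compound 3 stands at the top of the range, a lower number for compound 4 in this assay is expected, of moderate size, though the data do not fix how far.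

Compound 4 is therefore expected to give about 8000 nM in this assay, within a range of 2000 nM to 32000 nM, which would mean a step of a 7.9-fold lower number from compound 3 to compound 4 (0.90 log units; beyond the scatter).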

Compound 4, half-maximal inhibitory concentration: 39800 nM
The estimate for compound 4 lay 5.0-fold (0.70 log units) below the measured number, and the stated range ends below it.
By their numbers in this assay, from the lowest: compounds 2 and 1 (each within the scatter of the next); then compounds 4 and 3 (each within the scatter of the next).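

In this assay, adding a second hetero atom to the ring on the triple-bonded carbon gives a 1.6-fold lower number from compound 3 to compound 4 (0.20 log units; within the scatter), so the two ring groups of compound 3 and compound 4 cannot be told apart here, and the ring with 2 hetero atoms does not bring the number back towards that of compound 2. The gap to compound 2 stays wide, at a 13-fold higher number from compound 2 to compound 4 (1.10 log units; beyond the scatter), which shows that the large step seen earlier with compound 3 is not confined to one ring group: among the three ring compounds, compound 2 stands alone on the low side. Against the open-chain group of compound 1 the result is a 6.3-fold higher number from compound 1 to compound 4 (0.80 log units; beyond the scatter), whereas compound 2 lay within the scatter of compound 1, so at this position a ring with an ethynyl-bearing outline does not by itself match the open chain.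

On these data alone, whether a plain benzene ring, or an amine or a carboxylic acid on the ring, would fall with compound 2 or with compound 3 and compound 4 remains open. Nothing given here accounts for why compound 2 parts from the other two ring compounds.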